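Swapping the Amine Ring in a Histamine H2 Binder

The compounds below may be only part of what the source reports. "The series", "measured", "known", "first", "only" and "open" are said of these compounds alone.

In an assay on isolated protein for binding affinity to histamine H2 receptor (Homo sapiens) (on this read-out higher numbers stand for weaker inhibition and lower numbers for stronger inhibition), compound 2 `N#Cc1ccc(-c2ccc(OCCCN3CCCNCC3)cc2)cc1` gives 7760 nM, the lower of the two numbers in hand; the other, compound 1 `CCOC(=O)N1CCN(CCCOc2ccc(-c3c[nH]cn3)cc2)CC1`, gives 69200 nM, a gap that lies beyond the scatter. Compound 3 `C[C@@H]1CC[C@@H](C)N1CCCOc1ccc(-c2ccc(C#N)cc2)cc1` is drawn from compound 2 by a single change: 2,5-dimethylpyrrolidin-1-yl in place of 1,4-diazepan-1-yl on a saturated chain carbon, three bonds along the chain from an oxygen on an aromatic ring. Among the measured compounds shown here, no measured pair shows the effect of this exact change, so the expectation rests only on the two values above. Since compound 1 and compound 2 differ in many places at once, they give little guidance on what this one change does. The expected step of a 1.5-fold higher number from compound 2 to compound 3 (0.19 log units; within the scatter) is therefore small, with no confident direction and possibly nothing beyond the scatter. On that basis compound 3 is estimated at 12000 nM, within a range from 3000 nM to 50000 nM in this assay.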

Compound 3, inhibition constant: 9120 nM
Estimate against measurement, compound 3: 1.3-fold (0.12 log units) above; the range from low to high includes it.
By their numbers in this assay, from the lowest: compounds 2 and 3 (each within the scatter of the next); then compound 1.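

In this assay, the step at this position, a 1.2-fold higher number from compound 2 to compound 3 (0.07 log units; within the scatter), lies within the scatter, so these two rings cannot be told apart on this read-out. The change is not a small one on paper: the seven-membered ring with its two nitrogens and its hydrogen-bond donor gives way to a five-membered ring with one nitrogen, no such donor and two defined stereocentres, yet no measurable difference follows. Nothing on hand explains why the ring swap leaves the number within the scatter.

This single pair cannot show whether the two methyl groups or their stereocentres matter, which a plain pyrrolidin-1-yl ring would help to test. Also open, as far as these compounds go, is whether a piperidin-1-yl or morpholin-4-yl ring, or a longer chain to the amine, would behave the same way.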